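Replacing the 2-fluorophenyl group of compound 3

The source may hold more compounds than are shown below. What is called first, only, known or untested is meant among the compounds shown, and "the series" means these compounds.

Measured in a functional assay on OVCAR-3 cells (Homo sapiens) for antiproliferative activity, read by MTT assay, with a stated time of 24 h; on this read-out lower numbers stand for stronger inhibition and higher numbers for weaker inhibition:
compound 1 `O=C(NNc1ccccc1F)c1ccc(NS(=O)(=O)c2cnc(O)nc2O)cc1`: > 20000 nM (a limit)
compound 2 `O=C(NNc1ccccc1Cl)c1cccc(NS(=O)(=O)c2cnc(O)nc2O)c1`: 3350 nM
compound 3 `O=C(NNc1ccccc1F)c1cccc(NS(=O)(=O)c2cnc(O)nc2O)c1`: 17000 nM

The entry for compound 1 is a limit of this assay and not a number. Of the two actual numbers, compound 3 holds the higher at 17000 nM.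

Compound 4 `Cc1ccccc1C(=O)NNC(=O)c1cccc(NS(=O)(=O)c2cnc(O)nc2O)c1` carries (2-methylphenyl)carbonyl in place of 2-fluorophenyl on an amine nitrogen. Among the compounds with values here, the only measured step, a 5.1-fold higher number from compound 2 to compound 3 (0.71 log units; beyond the scatter), is a modest one and exchanges chloro for fluoro on an aromatic carbon. It leaves the amine nitrogen untouched, so it offers a rough scale for the size of a change and no direction. The expected step, a 1.7-fold lower number from compound 3 to compound 4 (0.23 log units; within the scatter), is therefore estimated to stay within the scatter, with wide uncertainty on either side. A reading at the limit of > 20000 nM in this assay, at which 1 of the 3 values shown sits, remains possible for compound 4. The estimate for compound 4 is 10000 nM, with an expected range from 2500 nM to 30000 nM.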

Compound 4, half-maximal inhibitory concentration: > 20000 nM
Compound 4: a limit, no number; the forecaster's own chance of this, stated with the estimate: 30%; middle value at least 2.0-fold (0.30 log units) away from the limit.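

In this assay compound 4 gives > 20000 nM, which is a limit of the assay and not a number. On the amine nitrogen, (2-methylphenyl)carbonyl in place of 2-fluorophenyl gives an at least 1.1-fold higher number from compound 3 to compound 4 (0.07 log units; that floor lies within the scatter), so this change has only a floor and no measured size, while (2-methylphenyl)carbonyl in place of 2-chlorophenyl gives an at least 5.9-fold higher number from compound 2 to compound 4 (0.77 log units; beyond the scatter), the first change at this amine nitrogen that is shown to raise the number beyond the scatter. With this result, a further weak member of the series may also return no number: the limit of > 20000 nM in this assay, at which 2 of the 4 values shown sit.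

From the compounds shown here alone, it remains open whether the carbonyl or the methyl group accounts for the rise. A benzoyl group or a 2-methylphenyl group on the same amine nitrogen would separate the two.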